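Sec-Butyl Ester in Place of the Furanylmethyl Ester

The source may hold more compounds than are shown below. What is called first, only, known or untested is meant among the compounds shown, and "the series" means these compounds.

The two measured compounds share one core, seen in compound 1 `COCCOC(=O)C(O)Cn1cnc2c(N)ncnc21` and compound 2 `Nc1ncnc2c1ncn2CC(O)C(=O)OCc1ccco1`. In a functional assay on PRK cells (Oryctolagus cuniculus) for cytotoxicity (a higher number here means that more compound is tolerated, a lower number that less compound is tolerated), compound 1 gives only a limit, > 400 ug/mL. Among the compounds with values here, compound 2 gives 40 ug/mL, the only number so far in this assay. Within the data shown here, the single measured step, an at least 10-fold lower number from compound 1 to compound 2 (1.00 log units; beyond the scatter), with compound 1 sitting at the limit of > 400 ug/mL in this assay, at which 1 of the 2 values shown sits, is the only guide to the change ahead.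

Compound 3 `CCC(C)OC(=O)C(O)Cn1cnc2c(N)ncnc21` differs from compound 2 by sec-butyl in place of (furan-2-yl)methyl on an oxygen next to a carbonyl group. The ring introduced in the measured step is thereby removed, and the ester returns to a small chain without a ring, as in compound 1. The step from compound 2 to compound 3 is therefore expected to run opposite to the measured one and may be of similar size, though one step is a rough guide. Compound 3 is estimated at 200 ug/mL, with a range from 60 ug/mL to 400 ug/mL, the expected step being a 5.0-fold higher number from compound 2 to compound 3 (0.70 log units; beyond the scatter).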

Compound 3, minimum cytotoxic concentration: > 400 ug/mL
Compound 3 gave a limit, no number; the forecaster's own chance of this, stated with the estimate: 40%; at least 2.0-fold (0.30 log units) between middle value and limit.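

Putting sec-butyl in place of (furan-2-yl)methyl on this ester oxygen gave an at least 10-fold higher number from compound 2 to compound 3 (1.00 log units; beyond the scatter) in this assay, so a second ester without a ring now stands apart from compound 2. Of the three esters shown, only compound 2, the one carrying the furan ring, gives a number rather than a limit, and the 2-methoxyethyl and sec-butyl esters cannot be told apart, since the step between those two cannot be read. Compound 3 joins compound 1 at the limit of the assay: the limit of > 400 ug/mL in this assay, at which 2 of the 3 values shown sit.

The compounds shown leave open whether the lower number belongs to the furan ring itself or to any ring on this ester. A benzyl ester or a longer chain such as n-octyl at this oxygen could separate those readings.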